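Hydrazinyl urea series: methoxy to fluoro on the aryl ring

A few compounds are considered here, and "the series" means these few. Any claim that something is new, unique, unknown or untested is made for them only; others in the source may bear on it.

Measured so far in a functional assay on HCT-116 cells (Homo sapiens) for cytotoxicity, read by MTT assay, with a stated time of 48 h, in the presence of a further agent that is not named here; on this read-out higher numbers stand for an effect only at larger amounts of compound and lower numbers for an effect already at smaller amounts:
compound 1, `COc1ccc(-c2cc(NNC(=O)Nc3cc(Cl)nc(OC)c3)nc3c2cnn3C)cc1`, gives 54200 nM
compound 2, `COc1cc(NC(=O)NNc2cc(-c3ccc(F)cc3)c3cnn(C)c3n2)cc(Cl)n1`, gives 75300 nM
compound 3, `CCCCOc1cc(NC(=O)NNc2cc(-c3ccc(OC)cc3)c3cnn(C)c3n2)cc(Cl)n1`, gives 36500 nM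

Compound 2 differs from compound 1 only as fluoro in place of methoxy on an aromatic carbon; the step in this assay is a 1.4-fold higher number from compound 1 to compound 2 (0.14 log units; within the scatter). Compound 3 differs from compound 1 as propyl in place of hydrogen on a saturated chain carbon bound to an oxygen on an aromatic ring, with a step of a 1.5-fold lower number from compound 1 to compound 3 (0.17 log units; within the scatter). Neither step leaves the scatter, and all three numbers sit close together, with compound 3 holding the lowest of them and compound 2 the highest.

Compound 4, `CCCCOc1cc(NC(=O)NNc2cc(-c3ccc(F)cc3)c3cnn(C)c3n2)cc(Cl)n1`, is not yet measured. It differs from compound 3 as fluoro in place of methoxy on an aromatic carbon. The place is the same word for word as in the change from compound 1 to compound 2, so this is the same change made once more on the core of compound 3. For the measured compounds named here, with only one earlier instance, the expectation rests on that single step, a 1.4-fold higher number from compound 1 to compound 2 (0.14 log units; within the scatter), carried over to compound 3.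

The step from compound 3 to compound 4 in this assay is expected to be a 1.4-fold higher number from compound 3 to compound 4 (0.15 log units; within the scatter). Compound 4 is therefore estimated at 51000 nM, between 25000 nM and 105000 nM.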

Compound 4, half-maximal effective concentration: 49400 nM
For compound 4 the middle estimate is 1.0-fold (0.01 log units) above the measured one, within the range that was stated.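

In this assay, fluoro in place of methoxy on the core of compound 3 gives a 1.4-fold higher number from compound 3 to compound 4 (0.13 log units; within the scatter), and this step agrees with the earlier one: the same change on two cores in this assay, a 1.4-fold higher number (0.14 log units; within the scatter) from compound 1 to compound 2 and a 1.4-fold higher number (0.13 log units; within the scatter) from compound 3 to compound 4, 1.0-fold (0.01 log units) apart, within the scatter of two such steps. Propyl in place of hydrogen on the chain at the oxygen, carried onto the core of compound 2, gives a 1.5-fold lower number from compound 2 to compound 4 (0.18 log units; within the scatter), and this step agrees with its earlier counterpart as well: the same change on two cores in this assay, a 1.5-fold lower number (0.17 log units; within the scatter) from compound 1 to compound 3 and a 1.5-fold lower number (0.18 log units; within the scatter) from compound 2 to compound 4, 1.0-fold (0.01 log units) apart, within the scatter of two such steps. Both changes therefore carry over between these cores as steps of matching size, but every step lies within the scatter, so this does not show that either change has a real effect on the read-out, and two cores set no rule for the wider series.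

On these data alone, it remains open whether a chloro group or an amine on that same aromatic carbon, or a longer chain on the oxygen, would give a step beyond the scatter. As far as these compounds go, it is also open whether a change of that larger size would carry from one core to another as closely as these small steps do.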